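Chloromethyl Carbonyl Extended by an Amino Link

This account rests on a few compounds, and the source may have more. Where it says the series, first, only, none or still open, it means among the compounds named here.

Compounds measured in a functional assay on K562 cells (Homo sapiens) for antiproliferative activity, read by MTT assay (a higher number here means a weaker inhibitor, a lower number a stronger inhibitor), so far
Compound 1 `CCCOC(=O)N1CCCc2cc(S(=O)(=O)N3CC(c4ccccc4)NC3=O)ccc21` gives > 20000 nM (a limit)
Compound 2 `O=C(CCl)N1CCCc2cc(S(=O)(=O)N3CC(c4ccccc4)NC3=O)ccc21` gives 1100 nM (a number)

Compound 1 reads > 20000 nM in this assay and that is a limit of the assay, not a number. Among the compounds with values here, compound 2, at 1100 nM in the same test, therefore holds the only true number so far.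

Compound 3 `O=C(CCl)NC(=O)N1CCCc2cc(S(=O)(=O)N3CC(c4ccccc4)NC3=O)ccc21` alters compound 2 on the same carbonyl carbon, with ((chloromethyl)carbonyl)amino in place of chloromethyl on a carbonyl carbon.

Within the data shown here, only one measured step bears on this, an at least 18-fold lower number from compound 1 to compound 2 (1.25 log units; beyond the scatter), which is large and brought in the chloromethyl on that carbonyl carbon. Compound 3 keeps this chloromethyl, now further out, so a return to the limit seen for compound 1 is not expected. As far as these compounds go, the new link is untested, however, so a modest move toward a higher number is expected, of a size near the scatter. The estimated change is a 1.5-fold higher number from compound 2 to compound 3 (0.16 log units; within the scatter) and it remains uncertain. The estimate for compound 3 is 1600 nM in this assay, with 450 nM to 6500 nM as the expected range.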

Compound 3, half-maximal inhibitory concentration: 515 nM
Compound 3: the middle estimate sits 3.1-fold (0.49 log units) above what was measured; the measured number falls inside the stated range.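

The carbonyl carbon that carries the chloromethyl in compound 2 accepts a larger group without loss in this assay: changing chloromethyl to ((chloromethyl)carbonyl)amino, which adds a hydrogen-bond donor and a hydrogen-bond acceptor, gives a 2.1-fold lower number from compound 2 to compound 3 (0.33 log units; beyond the scatter). The chlorine-bearing carbon therefore need not sit directly on that carbonyl carbon for the number to stay low, and replacing propoxy with the longer group gives an at least 38-fold lower number from compound 1 to compound 3 (1.58 log units; beyond the scatter). The value of compound 1 in that comparison is a limit, not a number: the limit of > 20000 nM in this assay, at which 1 of the 3 values shown sits.

The compounds shown leave open whether the chlorine is needed at all, as a plain methyl or a bromomethyl in its place on the extended group would separate the role of the halogen from that of the added amino link. As far as these compounds go, it also remains open how far the link can grow, for instance with a longer carbon chain between the two carbonyl groups, and whether the number would keep falling or turn back upward.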